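A few compounds are considered here, and "the series" means these few. Any claim that something is new, unique, unknown or untested is made for them only; others in the source may bear on it.

Working notes on the series. Compound 1 `COc1ccc(OCC(=O)Nc2cccc(NC(=O)c3ccc(N(C)C)cc3)c2)cc1OC` sits at the assay limit of > 10000 nM in this assay, at which 1 of the 3 values shown sits, in an assay on isolated protein for inhibition of Rho-associated protein kinase 2 (Homo sapiens), read by scintillation counting, radiometric assay and 33P incorporation, with a stated time of 40 min, in the presence of a further agent that is not named here (a higher number here means a weaker inhibitor, a lower number a stronger inhibitor), and gives > 10000 nM, which is a limit and not a number. Compound 2 `CCCc1ccc(C(=O)Nc2cccc(NC(=O)COc3ccc4c(=O)ccoc4c3)c2)cc1` gives 14 nM in this assay, the lowest of the two numbers shown. Compound 3 `CN(C)c1ccc(S(=O)(=O)Nc2cccc(NC(=O)COc3ccc4c(=O)ccoc4c3)c2)cc1` gives 263 nM in this assay, a gap to compound 2 that lies beyond the scatter. Compound 4 `O=C(COc1ccc2c(=O)ccoc2c1)Nc1cccc(NC(=O)c2ccc(C(=O)O)cc2)c1` is not yet measured; it differs from compound 2 as carboxy in place of propyl on an aromatic carbon. Among the compounds with values here, no pair of measured compounds shows this change on its own, so the expectation rests on the change itself. The expected step from compound 2 to compound 4 is a 21-fold higher number from compound 2 to compound 4 (1.33 log units; beyond the scatter), toward a weaker inhibitor. Compound 4 is estimated at 300 nM, within 50 nM to 3000 nM.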

Compound 4, half-maximal inhibitory concentration: 2030 nM
Estimate against measurement, compound 4: 6.8-fold (0.83 log units) below; low and high end bracket the measured number.
By their numbers in this assay, from the lowest: compound 2; then compound 3; then compound 4. At a limit, above all of these: compound 1.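

In this assay carboxy in place of propyl on this aromatic carbon gives a 150-fold higher number from compound 2 to compound 4 (2.16 log units; beyond the scatter) and so shows that the position is sensitive to the group it carries, even with the same count of heavy atoms entering and leaving. Within the data shown here, this is the first single change that can be read directly. The values shown give no cause for the step.

Going by these compounds, it remains open whether the step follows from the carboxy group entering or from the propyl chain leaving. A methyl ester, an amine or a longer chain at this place would help separate the two.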